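Trimming two carbons from the tail of compound 1

This account rests on a few compounds, and the source may have more. Where it says the series, first, only, none or still open, it means among the compounds named here.

Compound 1, with the structure `CCCCCCCCCCNC(=O)C1C(C(=O)O)[C@@H]2CC[C@H]1O2`, carries a decyl chain on an amide nitrogen attached to a bicyclic acid core. In an ADME assay on SW480 cells (Homo sapiens) for cytotoxicity, read by MTT assay, with a stated time of 72 h (a lower number here means a stronger inhibitor of growth, a higher number a weaker inhibitor of growth), compound 1 gives 10000 nM. Two companions share that core with different amide substituents: compound 2, `CCOC(=O)c1cn[nH]c1NC(=O)C1C(C(=O)O)[C@@H]2CC[C@H]1O2`, gives 10000 nM, and compound 3, `O=C(O)c1ccc(NC(=O)C2C(C(=O)O)[C@@H]3CC[C@H]2O3)cc1Cl`, gives 10000 nM. All three values sit at the same figure, so none of the three compounds can be set apart from the others in this assay; the change in the amide substituent has so far left the read-out where it was.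

Compound 4, `CCCCCCCCNC(=O)C1C(C(=O)O)[C@@H]2CC[C@H]1O2`, is the next step from compound 1. The change is hydrogen in place of ethyl on a saturated chain carbon, eight bonds along the chain from an amide-type nitrogen. For the measured compounds named here, no step between two measured compounds is available to set a scale for shortening the chain. Since compounds 1, 2 and 3 all gave the same figure with quite different amide groups, no movement beyond the scatter is expected in this assay. The estimate for compound 4 is 10000 nM, with a range from 5000 nM to 20000 nM, meaning an expected step of no change at the digits printed from compound 1 to compound 4 (within the scatter).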

Compound 4, concentration for 50% growth inhibition: 10000 nM
Compound 4: middle estimate and measured number agree at the digits printed; the measured number falls inside the stated range.
By their numbers in this assay, from the lowest: compounds 1, 2, 3 and 4 (each within the scatter of the next).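

For the compounds shown here, this is the first pair in the set that differs in one place only, so the chain can be judged on its own. In this assay, going by these compounds alone, the step reads no change at the digits printed from compound 1 to compound 4 (within the scatter) and gives a direct answer the earlier compounds could not: removing ethyl at this far end of the chain produces no shift beyond the scatter. No measurement on hand explains this flat result.

Still open, as far as these compounds go, is whether a longer chain, or an amine or a hydroxyl at the chain end, would shift the read-out away from the figure shared by these compounds. Also open, from the compounds shown here alone, is what a methyl ester would do in place of the carboxylic acid on the shared core.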